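Isopropyl on the urea nitrogen of a chlorobenzyl triazole

A few compounds are considered here, and "the series" means these few. Any claim that something is new, unique, unknown or untested is made for them only; others in the source may bear on it.

In a functional assay on MCF7 cells (Homo sapiens) for cytotoxicity, read by MTT assay, with a stated time of 72 h (on this read-out lower numbers stand for stronger inhibition and higher numbers for weaker inhibition), compound 1 `CC(C)NC(=O)N1CCN(C(=S)SCc2cn(Cc3ccccc3F)nn2)CC1` gives 1860 nM. Compound 2 `NC(=O)N1CCN(C(=S)SCc2cn(Cc3ccc(Cl)cc3)nn2)CC1` stands apart: in this assay it gives only a limit, > 128000 nM, and no number. That limit, (the limit of > 128000 nM in this assay, at which 1 of the 2 values shown sits), marks the edge of what this assay reports. Compound 3 `CC(C)NC(=O)N1CCN(C(=S)SCc2cn(Cc3ccc(Cl)cc3)nn2)CC1` has not been measured. It differs from compound 2 by one change, isopropyl in place of hydrogen on an amide-type nitrogen. Among the compounds with values here, no measured pair shows this change on its own, so its size can only be guessed. The account expects that compound 3 will give a number inside this assay rather than a limit, a step of an at least 32-fold lower number from compound 2 to compound 3 (1.50 log units; beyond the scatter) in the direction of stronger inhibition. Compound 3 is accordingly estimated at 4000 nM, within a range from 900 nM to 30000 nM, with some chance that only a limit is seen again.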

Compound 3, half-maximal inhibitory concentration: > 128000 nM
Compound 3 ended at the assay's limit (the forecaster's own chance of this, stated with the estimate: 20%); middle value at least 32-fold (1.50 log units) away from the limit.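

With 4-chlorophenyl kept, isopropyl on the amide-type nitrogen does not bring a number inside this assay, and the steps from compound 2 cannot be read: the limit of > 128000 nM in this assay, at which 2 of the 3 values shown sit.

The visible difference lies instead in the other change, with an at least 68-fold higher number from compound 1 to compound 3 (1.83 log units; beyond the scatter) when 4-chlorophenyl stands in place of 2-fluorophenyl on a saturated chain carbon bound to an aromatic nitrogen. Compound 1 and compound 3 share the isopropyl, so that group alone does not account for the readable value of compound 1.

Going by these compounds, what hydrogen on that nitrogen would give alongside 2-fluorophenyl stays open. So does whether a longer chain on the nitrogen, or phenyl or 4-fluorophenyl in place of 4-chlorophenyl, would return a number.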